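A few compounds are considered here, and "the series" means these few. Any claim that something is new, unique, unknown or untested is made for them only; others in the source may bear on it.

Measured so far:
compound 1, `O=C(NCc1cc(Cl)ccc1-n1cnnn1)[C@@H]1C[C@@H]2C[C@@H]2N1C(=O)[C@H](O)Cc1ccccn1`: 1.2 10^-6 cm/s
compound 2, `O=C(NCc1cc(Cl)ccc1-n1cnnn1)[C@@H]1[C@@H]2C[C@@H]2CN1C(=O)[C@H](O)c1ccccc1`: 2.2 10^-6 cm/s

Both were run in an ADME assay on Caco-2 cells (Homo sapiens) for permeability, read by LC-MS, in the apical to basolateral direction, with a stated time of 60 min, at pH 6.5; a lower number here means that the compound crosses the layer more slowly, a higher number that the compound crosses the layer faster. Compound 2 and compound 1 sit within the usual scatter of one another in this assay, so the two numbers cannot be told apart; neither compound stands out from the other on what has been measured.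

The next step goes from compound 2 to compound 3, `CC(C)(C)[C@@H](O)C(=O)N1C[C@H]2C[C@H]2[C@H]1C(=O)NCc1cc(Cl)ccc1-n1cnnn1`. The change, computed from the two structures, is tert-butyl in place of phenyl on a saturated chain carbon bound to a carbonyl carbon and an oxygen on a saturated carbon. Nothing else in the molecule moves; the shared core and the rest of the amide side stay as in compound 2.

Within the data shown here, with no step of this kind measured, the expectation for compound 3 in this assay rests only on compound 2, which gives 2.2 10^-6 cm/s. The estimated step of a 1.1-fold lower number from compound 2 to compound 3 (0.04 log units; within the scatter) is taken as none beyond the scatter, in either direction. Compound 3 is therefore expected to give about 2 10^-6 cm/s in this assay, with a range from 0.9 10^-6 cm/s to 4.5 10^-6 cm/s.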

Compound 3, apparent permeability: 3.8 10^-6 cm/s
Compound 3: the middle estimate sits 1.9-fold (0.28 log units) below what was measured; low and high end bracket the measured number.
By their numbers in this assay, from the lowest: compounds 1, 2 and 3 (each within the scatter of the next, the first and the last beyond it).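

At this position, on a saturated chain carbon bound to a carbonyl carbon and an oxygen on a saturated carbon, the series now has its first single-place reading: in this assay, tert-butyl in place of phenyl gives a 1.7-fold higher number from compound 2 to compound 3 (0.24 log units; within the scatter) and the two compounds cannot be told apart. The six-membered aromatic ring of carbon can therefore be exchanged here for a group with no ring and fewer heavy atoms without a step beyond the scatter in this assay. Nothing measured on hand bears on this result.

The compounds shown leave open how this assay reads with an amine, a carboxylic acid or a longer chain in place of tert-butyl at this position. On these data alone, a methoxy group in place of the hydroxy of the 1-hydroxy-2,2-dimethylpropyl group is equally open.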